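Cyano versus methoxycarbonyl on the chain of the stilbene-like series

This account rests on a few compounds, and the source may have more. Where it says the series, first, only, none or still open, it means among the compounds named here.

Measured so far in a functional assay on HCT-116 cells (Homo sapiens) for cytotoxicity, read by scintillation counting and thymidine incorporation, with a stated time of 72 h; a lower number here means a stronger inhibitor, a higher number a weaker inhibitor:
compound 1, `COc1cc(OC)cc(/C(=C/C#N)c2ccc(OC)c(OC)c2)c1`: 110 nM
compound 2, `COC(=O)C=C(c1cc(OC)cc(OC)c1)c1ccc(OC)c(OC)c1`: > 10000 nM

Compound 2 sits at the upper limit of this assay; its value of > 10000 nM is a limit, not a number, and is the point noted as the limit of > 10000 nM in this assay, at which 1 of the 2 values shown sits. Compound 1, by contrast, gives a real number in this assay, 110 nM.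

The next compound, compound 3 with structure `COc1cc(OC)cc(C(=CC#N)c2ccc(OC)c(OC)c2)c1`, differs from compound 2 in one place: cyano in place of methoxycarbonyl on a double-bonded chain carbon bound to a double-bonded chain carbon. The change puts the same cyano on the chain that compound 1 carries, so compound 3 is expected to fall close to compound 1 rather than to compound 2. The step in this assay from compound 2 to compound 3 is therefore expected to be large and toward stronger inhibition, an at least 66-fold lower number from compound 2 to compound 3 (1.82 log units; beyond the scatter). Since compound 2 is known only as a limit, the size of that step cannot be pinned down.

Compound 3 is estimated at 150 nM in this assay, with a range from 60 nM to 500 nM, the spread allowing for the geometry of the double bond being unspecified.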

Compound 3, half-maximal inhibitory concentration: 18 nM
Compound 3: the middle estimate sits 8.3-fold (0.92 log units) above what was measured; measured number below the stated range.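

In this assay, cyano in place of methoxycarbonyl on a double-bonded chain carbon bound to a double-bonded chain carbon now has a direct reading in a single pair: an at least 550-fold lower number from compound 2 to compound 3 (2.74 log units; beyond the scatter). Compound 2 remains a limit and not a number, so this step gives only a minimum size: the limit of > 10000 nM in this assay, at which 1 of the 3 values shown sits. The pair with the same atoms and bonds adds something the earlier comparison of groups could not show, since a 6.1-fold lower number from compound 1 to compound 3 (0.79 log units; beyond the scatter), and the drawing of the double bond is the only thing that separates these two cyano compounds: the fact that one of compounds 1 and 3 is drawn with a defined configuration and the other without, at the place where they differ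

Compound 3 carries no drawn configuration, so the compounds shown do not tell which geometry of the double bond goes with the lower number, or what form of the double bond the value of compound 3 reflects. Also open, from the compounds shown here alone, is how far the result at this place is specific to cyano, since a carboxylic acid or a primary amide on that chain carbon would be needed to tell whether methoxycarbonyl is the exception or cyano is.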